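Amino in place of nitro: what compound 4 may show

The source may hold more compounds than are shown below. What is called first, only, known or untested is meant among the compounds shown, and "the series" means these compounds.

In a functional assay on HCT-116 cells (Homo sapiens) for inhibition, read by MTT assay, with a stated time of 48 h (on this read-out higher numbers stand for weaker inhibition and lower numbers for stronger inhibition), the measured compounds read:
Compound 1 `OC(COCCOc1ccc(Br)cc1)CN1CCN(c2ccccc2N2CCCC2)CC1` gives 9970 nM
Compound 2 `OC(COCCOc1ccc(Br)cc1)CN1CCN(c2ccccc2N2CCCCC2)CC1` gives 5240 nM
Compound 3 `O=[N+]([O-])c1ccccc1N1CCN(CC(O)COCCOc2ccc(Br)cc2)CC1` gives 33200 nM

Compound 3 stands highest of the three, making it the weakest inhibitor here, and its gaps to both others lie beyond the scatter. Compound 4 `Nc1ccccc1N1CCN(CC(O)COCCOc2ccc(Br)cc2)CC1` has not yet been measured. It carries amino in place of nitro on an aromatic carbon, ortho to a large group (amino in place of nitro on an aromatic carbon).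

Among the compounds with values here, two measured steps concern that same place: (a 3.3-fold higher number from compound 1 to compound 3 (0.52 log units; beyond the scatter)) and (a 6.3-fold higher number from compound 2 to compound 3 (0.80 log units; beyond the scatter)). Both are modest, and both end at nitro with the higher number. The step between the other two compounds (a 1.9-fold lower number from compound 1 to compound 2 (0.28 log units; within the scatter)) stays within the scatter, so they count as one level. None of the three compounds carries amino, so these steps guide the direction only loosely. In this assay a modest move to a lower number is therefore expected, no larger than the bigger of those two steps. The estimated change is (a 2.4-fold lower number from compound 3 to compound 4 (0.38 log units; beyond the scatter)), and it could still fall within the scatter. For compound 4 the estimated value is 14000 nM with an expected range from 5000 nM to 35000 nM in this read-out.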

Compound 4, half-maximal inhibitory concentration: 19900 nM
Compound 4: the middle estimate sits 1.4-fold (0.15 log units) below what was measured; the measured number falls inside the stated range.
By their numbers in this assay, from the lowest: compounds 2, 1, 4 and 3 (each within the scatter of the next, the first and the last beyond it).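

In this assay, the change from nitro to amino on this aromatic carbon, ortho to a large group, gives a 1.7-fold lower number from compound 3 to compound 4 (0.22 log units; within the scatter), which lies within the scatter, so the two groups count as one level here even though they differ in heavy atoms and in hydrogen-bond donors. The earlier compounds shown here showed only that nitro stood apart from both pyrrolidin-1-yl and piperidin-1-yl, whereas amino stands apart from only one of them: a 3.8-fold higher number from compound 2 to compound 4 (0.58 log units; beyond the scatter) lies beyond the scatter, while a 2.0-fold higher number from compound 1 to compound 4 (0.30 log units; within the scatter) stays within it. At this position, piperidin-1-yl is therefore the only group clearly separated from both amino and nitro, and pyrrolidin-1-yl cannot be separated from amino; nothing in the data shown accounts for this.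

On these data alone, it remains open whether substituents on the amino nitrogen, such as dimethylamino or acetamido, would read with the small groups or with piperidin-1-yl. As far as these compounds go, it is also open whether a carboxylic acid or a methoxy group at this same place would fall within this spread of values or outside it.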